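A few compounds are considered here, and "the series" means these few. Any claim that something is new, unique, unknown or untested is made for them only; others in the source may bear on it.

Compound 1 `OC[C@@H](O)[C@H]1O[C@@H](n2cnc3c(Cl)ncnc32)[C@H](O)[C@@H]1O`. In a functional assay on MCF7 cells (Homo sapiens), read by colorimetric assay, with a stated time of 96 h (on this read-out lower numbers stand for stronger inhibition and higher numbers for weaker inhibition), compound 1 gives > 100000 nM, which is a limit of the assay.
Compound 2 `OC[C@@H](O)[C@H]1O[C@@H](n2cnc3c(Cl)nc(Cl)nc32)[C@H](O)[C@@H]1O`. In this assay compound 2 gives 54200 nM.
Compound 3 `CC(=O)OC[C@@H](OC(C)=O)[C@H]1O[C@@H](n2cnc3c(Cl)ncnc32)[C@H](OC(C)=O)[C@@H]1OC(C)=O`. In this assay compound 3 gives > 100000 nM, again a limit of the assay.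

For the measured compounds named here, the one measured step is chloro in place of hydrogen on an aromatic carbon, giving an at least 1.8-fold lower number from compound 1 to compound 2 (0.26 log units; that floor lies within the scatter). As the starting point is a limit, the true size of that step is not fixed; it rests on (the limit of > 100000 nM in this assay, at which 2 of the 3 values shown sit).

Compound 3 and compound 1 share no counted difference: the difference between the two cores is not broken down here.

Compound 4 `CC(=O)OC[C@@H](OC(C)=O)[C@H]1O[C@@H](n2cnc3c(Cl)nc(Cl)nc32)[C@H](OC(C)=O)[C@@H]1OC(C)=O` is not yet measured. It carries the same change relative to compound 3, namely (chloro in place of hydrogen on an aromatic carbon), at a place described in the same words as for compound 2.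

For compound 4 the step is expected to be an at least 1.4-fold lower number from compound 3 to compound 4 (0.15 log units; that floor lies within the scatter), resting on an at least 1.8-fold lower number from compound 1 to compound 2 (0.26 log units; that floor lies within the scatter), with the same reservation that compound 3 sits at the limit > 100000 nM. Compound 4 is therefore estimated at 70000 nM, between 25000 nM and 200000 nM, with a real chance that only a limit is returned.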

Compound 4, half-maximal inhibitory concentration: 22400 nM
For compound 4 the middle estimate is 3.1-fold (0.49 log units) above the measured one, outside the stated range (below it).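

In this assay, chloro in place of hydrogen on an aromatic carbon gives an at least 4.4-fold lower number from compound 3 to compound 4 (0.64 log units; beyond the scatter), so the change also goes with a lower number on a second core, and here the floor of the step lies beyond the scatter. Set side by side, the two steps do not show whether the size of the change depends on the core: the same change on two cores in this assay, an at least 1.8-fold lower number (0.26 log units; that floor lies within the scatter) from compound 1 to compound 2 and an at least 4.4-fold lower number (0.64 log units; beyond the scatter) from compound 3 to compound 4; the limit leaves it open whether they differ. Compound 1 and compound 3 both start from a limit, so each step is only a floor and neither true size is known, which also means that two cores show the direction and nothing more: the limit of > 100000 nM in this assay, at which 2 of the 4 values shown sit.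

Still open, from the compounds shown here alone, is whether an amine or a methoxy group, in place of the chloro between two ring nitrogen atoms, would go with a lower or a higher number than the chloro does. Also open, going by these compounds, is how a longer ester chain in place of the acetyl esters would read on the core of compound 4.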